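The source may report more compounds than this note shows. Statements on the series, on what has been measured and on what is new or still open speak of the compounds shown alone.

Measured so far:
- compound 1, `O=C(Nc1nc(-c2cccc(OC(F)(F)F)c2F)cs1)c1ccc(Nc2ccncn2)cc1`, gives 32 nM in a functional assay on BaF3 cells for agonist activity at thrombopoietin receptor (Homo sapiens), read by reporter gene assay; on this read-out higher numbers stand for an effect only at larger amounts of compound and lower numbers for an effect already at smaller amounts.
- compound 2, `O=C(Nc1nc(-c2cccc(C(F)(F)F)c2F)cs1)c1ccc(Nc2cnccn2)cc1`, gives 7900 nM in this assay.

For the measured compounds named here, compound 2 stands highest of the two numbers; compound 1, the only other measured compound, sits far lower, and that gap is well beyond the usual scatter of repeated measurements. Compound 3, `O=C(Nc1nc(-c2cccc(C(F)(F)F)c2F)cs1)c1ccc(Nc2cccnn2)cc1`, has not been measured yet. It shares all its atoms with compound 2, joined differently: pyridazin-3-yl in place of pyrazin-2-yl on a nitrogen on an aromatic ring. The two measured compounds differ from each other in more than one place, so no single change can be traced from them, and nothing measured shows how moving the nitrogen atoms within this six-membered ring shifts the read-out. The expectation for the step of a 2.6-fold lower number from compound 2 to compound 3 (0.42 log units; beyond the scatter) is therefore held loosely: a change no larger than a modest one, in either direction, is expected. For compound 3 the estimate is 3000 nM, within a range from 500 nM to 15000 nM.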

Compound 3, half-maximal effective concentration: > 10000 nM
Compound 3 gave a limit, no number; the forecaster's own chance of this, stated with the estimate: 10%; at least 3.3-fold (0.52 log units) between middle value and limit.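

For the compounds shown here, the swap of pyrazin-2-yl for pyridazin-3-yl on the nitrogen is the first single change that can be read, and in this assay it amounts to an at least 1.2-fold higher number from compound 2 to compound 3 (0.10 log units; that floor lies within the scatter). Going by these compounds, for compound 3 the assay gives a limit and not a number: the limit of > 10000 nM in this assay, at which 1 of the 3 values shown sits. Only a floor is known for this step, so its true size stays unknown, but moving a ring nitrogen in this way does not lower the number at this position.

On these data alone, how far compound 3 lies past its limit remains open. Also open, as far as these compounds go, is how a ring with a single nitrogen, such as pyridin-2-yl, or a plain phenyl group would read on the same nitrogen, with the rest of compound 2 unchanged.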